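The compounds below may be only part of what the source reports. "The series", "measured", "known", "first", "only" and "open" are said of these compounds alone.

Compound 1 `O=C1O/C(=C\Cn2cc(-c3ccc(Br)cc3)nn2)C(OCc2ccccc2)=C1OCc1ccccc1`: > 100000 nM
Compound 2 `CCCCCc1ccc(-c2cn(C/C=C3\OC(=O)C(OCc4ccccc4)=C3OCc3ccccc3)nn2)cc1`: > 100000 nM
Compound 3 `CC(C)(C)c1cn(C[C@H](O)[C@H]2OC(=O)C(OCc3ccccc3)=C2OCc2ccccc2)nn1`: 28300 nM

In a functional assay on HCT-116 cells (Homo sapiens) for antiproliferative activity, read by MTT assay, with a stated time of 72 h (a lower number here means a stronger inhibitor, a higher number a weaker inhibitor), compound 2 gives only a limit, > 100000 nM. Compound 1 likewise gives only a limit in this assay, > 100000 nM. Compound 3 gives a number, 28300 nM. Compound 4 `O=C1O/C(=C\Cn2cc(-c3cccc(O)c3)nn2)C(OCc2ccccc2)=C1OCc1ccccc1` differs from compound 2 in one place: 3-hydroxyphenyl in place of 4-pentylphenyl on an aromatic carbon. For the measured compounds named here, the one measured step between compounds differing in one place, a step that the two limits leave unreadable from compound 1 to compound 2, joins two limits and is unreadable because the limit of > 100000 nM in this assay, at which 2 of the 3 values shown sit, holds both ends. Going by the values given here, no measured step bears on the change to compound 4, so its size is unknown. Compound 4 is therefore expected to stay near where compound 2 stands, an expected step of a number no higher from compound 2 to compound 4 (the limit leaves the size open). The estimate for compound 4 in this assay is 100000 nM, with a range from 30000 nM to 300000 nM.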

Compound 4, half-maximal inhibitory concentration: 63600 nM
Compound 4: middle estimate off by 1.6-fold (0.20 log units), on the high side, within the range that was stated.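

In this assay, compound 4 shows that this aromatic carbon can carry a group, 3-hydroxyphenyl, that gives the shared core a number rather than a limit. Replacing 4-pentylphenyl gives an at least 1.5-fold lower number from compound 2 to compound 4 (0.19 log units; that floor lies within the scatter), and replacing 4-bromophenyl gives an at least 1.5-fold lower number from compound 1 to compound 4 (0.19 log units; that floor lies within the scatter). Both are only floors, and their true size stays open because one end of each step sits at a limit: the limit of > 100000 nM in this assay, at which 2 of the 4 values shown sit.

Still open, going by these compounds, is whether the hydroxyl itself or its place on the phenyl ring accounts for the number, and what a plain phenyl or an aminophenyl would give on this carbon.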